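The compounds below may be only part of what the source reports. "The series", "measured", "known", "first", "only" and "open" are said of these compounds alone.

Measured in a functional assay on Ehrlich cells (Mus musculus) for antiproliferative activity, read by trypan blue exclusion, with a stated time of 2 h, tested at 100 ug/mL; a lower number here means a weaker effect, a higher number a stronger effect of the compound at the concentration tested:
compound 1 `N#CC1=C(N)N(c2ccc(S(N)(=O)=O)cc2)C2=C(C(=O)CCC2)C1/C=C/c1ccccc1` gives 45%
compound 2 `N#CC1=C(N)N(c2ccc(S(N)(=O)=O)cc2)C2=C(C(=O)CCC2)C1c1cccc([N+](=O)[O-])c1` gives 71%
compound 3 `N#CC1=C(N)N(c2ccc(S(N)(=O)=O)cc2)C2=C(C(=O)CCC2)C1c1ccc([N+](=O)[O-])cc1` gives 100%

Compound 3 stands highest of the three numbers. Compound 2 is nearest to it, with a number 29 percentage points higher from compound 2 to compound 3 (beyond the scatter), and compound 1 is furthest, with a number 55 percentage points higher from compound 1 to compound 3 (beyond the scatter); both gaps are beyond the scatter, as is a number 26 percentage points higher from compound 1 to compound 2 (beyond the scatter). All three compounds share one core and differ only in the group on the saturated ring carbon, so within this set that group alone moves the read-out in this assay.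

Compound 4 `COc1ccc(C2C(C#N)=C(N)N(c3ccc(S(N)(=O)=O)cc3)C3=C2C(=O)CCC3)c2ccccc12` is not yet measured. It differs from compound 3 in one place: 4-methoxynaphthalen-1-yl in place of 4-nitrophenyl on a saturated ring carbon. For the measured compounds named here, no measured step covers this exchange; what bears on it is that every measured step changed the same position and each shifted the read-out beyond the scatter, a number 55 percentage points higher from compound 1 to compound 3 (beyond the scatter) being the largest, so the position is sensitive and a change there is unlikely to stay within the scatter. As compound 3 already sits at the top of the three, the expected move from compound 3 to compound 4 is downward and of modest to large size, a number 40 percentage points lower from compound 3 to compound 4 (beyond the scatter). Compound 4 is therefore estimated at 60% in this assay, with a range from 30% to 90%.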

Compound 4, a percentage reported as activity, at one concentration (the size of the read-out at that concentration, not a potency): 90%
Estimate against measurement, compound 4: 30 percentage points below; low and high end bracket the measured number.
By their numbers in this assay, from the lowest: compound 1; then compound 2; then compounds 4 and 3 (each within the scatter of the next).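

In this assay, for the compounds shown here, replacing 4-nitrophenyl with 4-methoxynaphthalen-1-yl on the saturated ring carbon is the first change at this position that does not separate two compounds beyond the scatter (a number 10 percentage points lower from compound 3 to compound 4 (within the scatter)). A high read-out here therefore does not depend on a nitro group or on a single six-membered aromatic ring: compound 4 has neither, yet it stands clear of the 3-nitrophenyl compound (a number 19 percentage points higher from compound 2 to compound 4 (beyond the scatter)) and the 2-phenylethenyl compound (a number 45 percentage points higher from compound 1 to compound 4 (beyond the scatter)), while compound 2 shows that carrying a nitro group does not by itself reach the level of compounds 3 and 4. No supporting data bear on why these groups rank as they do.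

The compounds shown do not separate the methoxy group from the second aromatic ring, so the contribution of each to the read-out of compound 4 remains open, as would be tested by plain naphthalen-1-yl or 4-methoxyphenyl at this carbon. On these data alone, all four groups on this carbon are unsaturated carbon-based groups with aromatic rings, so it also remains open whether a saturated alkyl chain, an amine or a carboxylic acid there would keep the read-out at this level.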